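The compounds below may be only part of what the source reports. "The series", "measured", "known", "first", "only" and "open" are said of these compounds alone.

Compound 1 `COC(=O)[C@@]1(C)CCC=C2[C@@H]1CC[C@@H](C)[C@]2(C)Cc1c(C)[nH]c2ccc(C)cc12` is the reference point of the set; in a functional assay on WiDr cells (Homo sapiens) for inhibition, read by sulforhodamine B assay, with a stated time of 48 h (a higher number here means a weaker inhibitor of growth, a lower number a stronger inhibitor of growth), compound 1 gives 28000 nM. Compound 2 `COC(=O)[C@@]1(C)CCC=C2[C@@H]1CC[C@@H](C)[C@]2(C)Cc1c(C)[nH]c2ccc(Br)cc12` differs from it only by bromo in place of methyl on an aromatic carbon; in this assay compound 2 gives 15000 nM, and the step is a 1.9-fold lower number from compound 1 to compound 2 (0.27 log units; within the scatter). Compound 3 `COC(=O)[C@@]1(C)CCC=C2[C@@H]1CC[C@@H](C)[C@]2(C)Cc1c(C)[nH]c2c(C)cccc12` has the same atoms as compound 1 joined differently; the difference between the two cores is not broken down here. In this assay compound 3 gives 21000 nM, close to the numbers of compound 1 and compound 2, within the usual scatter in both cases.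

Compound 4 `COC(=O)[C@@]1(C)CCC=C2[C@@H]1CC[C@@H](C)[C@]2(C)Cc1c(C)[nH]c2c(Br)cccc12` is not yet measured. It relates to compound 3 through (bromo in place of methyl on an aromatic carbon). This is the same kind of change as that from compound 1 to compound 2, but not the same: in compound 2 the bromo sits meta to a fused ring and para to a fused ring, whereas in compound 4 it sits ortho to a fused ring and meta to a fused ring. Because the earlier step was a 1.9-fold lower number from compound 1 to compound 2 (0.27 log units; within the scatter), the expected step for compound 4 is a 1.8-fold lower number from compound 3 to compound 4 (0.24 log units; within the scatter), resting on that single precedent. Compound 4 is therefore estimated at 12000 nM, with a range from 5000 nM to 30000 nM.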

Compound 4, concentration for 50% growth inhibition: 38000 nM
Estimate against measurement, compound 4: 3.2-fold (0.50 log units) below, and the stated range ends below it.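

Bromo in place of methyl on an aromatic carbon gives, in this assay, a 1.8-fold higher number from compound 3 to compound 4 (0.26 log units; within the scatter), a step that taken alone stays within the scatter. Set beside the earlier step, the change does not carry over between the two cores as one fixed shift: the same change on two cores in this assay, a 1.9-fold lower number (0.27 log units; within the scatter) from compound 1 to compound 2 and a 1.8-fold higher number (0.26 log units; within the scatter) from compound 3 to compound 4, 3.4-fold (0.53 log units) apart, beyond the scatter of two such steps This comparison rests on only two pairs, each step within the scatter on its own, and it does not show what accounts for the gap, nor that bromo reliably strengthens or weakens growth inhibition on either core.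

The compounds shown leave open whether chloro or methoxy on these same aromatic carbons would follow either step. On these data alone, it also remains open whether larger departures, such as an amine or a longer chain on the aromatic ring, or a carboxylic acid in place of the methyl ester, would move the number beyond the scatter.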